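Methoxy and bromo variation in a small hydrazone set

A few compounds are considered here, and "the series" means these few. Any claim that something is new, unique, unknown or untested is made for them only; others in the source may bear on it.

Compound 1 `COc1cc(/C=N/Nc2nc(-c3ccccc3)cs2)c(Br)c(Br)c1OC` is the reference point of the set. In a functional assay on A549 cells (Homo sapiens) for inhibition, read by MTT assay, with a stated time of 48 h (on this read-out lower numbers stand for stronger inhibition and higher numbers for weaker inhibition), compound 1 gives 15300 nM. Compound 2 `COc1ccccc1-c1csc(N/N=C/c2cc(OC)c(OC)c(Br)c2Br)n1` adds a methoxy group, (methoxy in place of hydrogen on an aromatic carbon); in this assay compound 2 gives 85100 nM, which is a 5.6-fold higher number from compound 1 to compound 2 (0.75 log units; beyond the scatter). Compound 3 `COc1cc(/C=N/Nc2nc(-c3ccccc3)cs2)cc(Br)c1OC` differs from compound 1 in its core, (hydrogen in place of bromo on an aromatic carbon); in this assay compound 3 gives 40000 nM, which is a 2.6-fold higher number from compound 1 to compound 3 (0.42 log units; beyond the scatter). Compound 3 stands second highest of the three numbers, nearest to compound 2 and furthest from compound 1.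

Compound 4 `COc1ccccc1-c1csc(N/N=C/c2cc(Br)c(OC)c(OC)c2)n1` has not been measured. It relates to compound 3 as compound 2 relates to compound 1: methoxy in place of hydrogen on an aromatic carbon. The same change occurs once already in the set and gave a 5.6-fold higher number from compound 1 to compound 2 (0.75 log units; beyond the scatter). The surroundings of the place are described in the same words for both pairs, so the change is taken as the same one. The two cores differ only by the bromo change (hydrogen in place of bromo on an aromatic carbon).

With one earlier case to rest on, the step from compound 3 to compound 4 in this assay is expected to be a 4.5-fold higher number from compound 3 to compound 4 (0.65 log units; beyond the scatter), slightly tempered because a single instance of a 5.6-fold higher number from compound 1 to compound 2 (0.75 log units; beyond the scatter) carries uncertainty. Compound 4 is estimated at 180000 nM, between 70000 nM and 500000 nM. Compound 3 already gives 40000 nM, and the number expected for compound 4 lies higher still.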

Compound 4, half-maximal inhibitory concentration: 94900 nM
The estimate for compound 4 lay 1.9-fold (0.28 log units) above the measured number, within the range that was stated.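

In this assay, the change from phenyl to 2-methoxyphenyl points the same way on the second core, with a 2.4-fold higher number from compound 3 to compound 4 (0.38 log units; beyond the scatter), and the two steps cannot be told apart: the same change on two cores in this assay, a 5.6-fold higher number (0.75 log units; beyond the scatter) from compound 1 to compound 2 and a 2.4-fold higher number (0.38 log units; beyond the scatter) from compound 3 to compound 4, 2.3-fold (0.37 log units) apart, within the scatter of two such steps. The bromo change gives a 1.1-fold higher number from compound 2 to compound 4 (0.05 log units; within the scatter), which lies within the scatter although its earlier counterpart lay beyond it, yet the gap between these two steps does not separate them either: the same change on two cores in this assay, a 2.6-fold higher number (0.42 log units; beyond the scatter) from compound 1 to compound 3 and a 1.1-fold higher number (0.05 log units; within the scatter) from compound 2 to compound 4, 2.3-fold (0.37 log units) apart, within the scatter of two such steps. The four compounds therefore fit a methoxy step that carries over between these two cores in direction, but two pairs in a single assay do not fix its size, do not show that the steps are equal, and say nothing about any other core.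

The compounds shown leave open how the number responds to other groups at this place on the phenyl ring, such as an amine, a carboxylic acid or a longer alkoxy chain in place of the methoxy. They also leave open whether chloro in place of bromo would read like bromo or like hydrogen on the shared core.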